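The source may hold more compounds than are shown below. What is called first, only, known or untested is meant among the compounds shown, and "the series" means these compounds.

Of the compounds shown here, three have so far been measured in a functional assay on MCF7 cells (Homo sapiens) for cytotoxicity, read by MTT assay, with a stated time of 24 h; a lower number here means a stronger inhibitor, a higher number a weaker inhibitor. Compound 2 `Cc1cc(-c2nc3ccccc3o2)ccc1NC(=O)CN1CCN(CCCN(C)C)CC1` gives 11300 nM in this assay. Compound 1 `Cc1cc(-c2nc3cc(Cl)ccc3o2)ccc1NC(=O)CN1CCN(CCCN(C)C)CC1` differs from compound 2 only by chloro in place of hydrogen on an aromatic carbon, and in this assay compound 1 gives 63400 nM. That single change produced a 5.6-fold higher number from compound 2 to compound 1 (0.75 log units; beyond the scatter). Compound 3 `Cc1cc(-c2nc3ccccc3o2)ccc1NC(=O)CCl` shares the same aromatic portion but is built differently elsewhere; the difference between its core and that of compound 2 is not broken down here. In this assay compound 3 gives 29800 nM, which places it between the other two, higher than compound 2 and lower than compound 1, both gaps beyond the scatter.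

Compound 4 `Cc1cc(-c2nc3cc(Cl)ccc3o2)ccc1NC(=O)CCl` has not yet been measured. It stands to compound 3 as compound 1 stands to compound 2: the difference is chloro in place of hydrogen on an aromatic carbon, the same change at the same place on the shared core. Among the compounds shown this change occurs twice, and the one measured instance gave a higher number. Resting on a 5.6-fold higher number from compound 2 to compound 1 (0.75 log units; beyond the scatter), one would expect a step of about a 5.0-fold higher number from compound 3 to compound 4 (0.70 log units; beyond the scatter). Compound 4 is therefore expected to give roughly 150000 nM, with a plausible range from 50000 nM to 450000 nM, allowing for the scatter of repeated measurements and for the change not carrying over exactly to the core of compound 3.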

Compound 4, half-maximal inhibitory concentration: > 100000 nM
Compound 4 gave a limit, no number; the forecaster's own chance of this, stated with the estimate: 25%; the middle value lies beyond the limit too.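

In this assay compound 4 gives > 100000 nM, which is a limit of the assay and not a number. Chloro in place of hydrogen on an aromatic carbon moved the number in the same direction on both cores, here by an at least 3.3-fold higher number from compound 3 to compound 4 (0.52 log units; beyond the scatter), so in these two pairs, the only ones shown, the direction of the change carried from one core to the other. This does not show that the size of the change carried over, and a sharper comparison of the two steps is not possible: the same change on two cores in this assay, a 5.6-fold higher number (0.75 log units; beyond the scatter) from compound 2 to compound 1 and an at least 3.3-fold higher number (0.52 log units; beyond the scatter) from compound 3 to compound 4; the limit leaves it open whether they differ

The compounds shown have only hydrogen or chloro at this place, so it remains open whether fluoro, methoxy or a nitrile there would move the number in the same direction. As far as these compounds go, it also remains open whether the chloro step would hold on a core that carries a simple primary amine, a carboxylic acid or a longer chain in place of the groups on the amide carbonyl side of compound 2 and compound 3.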